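The source may report more compounds than this note shows. Statements on the series, on what has been measured and on what is new or still open speak of the compounds shown alone.

In an assay on VSM-A10 cells for antagonist activity at Endothelin-1 receptor (Rattus norvegicus) (on this read-out higher numbers stand for weaker inhibition and lower numbers for stronger inhibition), three compounds have been measured. Compound 1 `Cc1noc(NS(=O)(=O)c2ccc(NCc3ccccc3)cc2)c1C` gives 9800 nM, compound 2 `CCCNc1ccc(S(=O)(=O)Nc2onc(C)c2C)cc1` gives 27000 nM, and compound 3 `Cc1noc(NS(=O)(=O)c2ccc(N/C(S)=N/c3ccccc3)cc2)c1C` gives 4100 nM. Compound 2 therefore shows the highest number of the three: a 2.8-fold higher number from compound 1 to compound 2 (0.44 log units; beyond the scatter), and a 6.6-fold lower number from compound 2 to compound 3 (0.82 log units; beyond the scatter). Compound 4 `Cc1noc(NS(=O)(=O)c2ccc(F)cc2)c1C` differs from compound 2 in one place: fluoro in place of propylamino on an aromatic carbon. All three measured steps alter the group on that same aromatic nitrogen, and in each the smaller group went with the higher number, as in a 2.8-fold higher number from compound 1 to compound 2 (0.44 log units; beyond the scatter) and a 6.6-fold lower number from compound 2 to compound 3 (0.82 log units; beyond the scatter). Fluoro is the smallest group yet at this place, so compound 4 is expected to move further in that direction, by a 2.4-fold higher number from compound 2 to compound 4 (0.38 log units; beyond the scatter). Compound 4 is thus estimated at 65000 nM, ranging from 20000 nM to 200000 nM.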

Compound 4, half-maximal inhibitory concentration: 1000 nM
Beside the measured number, compound 4's estimate is 65-fold (1.81 log units) above it; the measured number lies below the stated range.
By their numbers in this assay, from the lowest: compound 4; then compound 3; then compound 1; then compound 2.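

In this assay fluoro brings a 27-fold lower number from compound 2 to compound 4 (1.43 log units; beyond the scatter) and a 9.8-fold lower number from compound 1 to compound 4 (0.99 log units; beyond the scatter) with no nitrogen on the ring at this place, so an amine there is not needed for inhibition. Size alone no longer orders the series: larger groups went with lower numbers across compound 1, compound 2 and compound 3, but compound 4 goes against that with the smallest group and the lowest number. Nothing available explains why this change has so large an effect. The compounds shown leave open whether fluoro itself matters or simply the loss of the amine. Chloro, methoxy or a plain hydrogen at this place would help separate the two.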